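Moving the methyl group along the amide aryl ring

The compounds below may be only part of what the source reports. "The series", "measured", "known", "first", "only" and "open" are said of these compounds alone.

Compound 1, `CCN1CCN(c2cc(C)c3cc(NC(=O)c4ccccc4F)ccc3n2)CC1`, gives 38100 nM in a functional assay on SK-BR-3 cells (Homo sapiens) for antiproliferative activity, read by MTT assay, with a stated time of 72 h; on this read-out lower numbers stand for stronger inhibition and higher numbers for weaker inhibition.
Compound 2, `CCN1CCN(c2cc(C)c3cc(NC(=O)c4ccccc4C)ccc3n2)CC1`, gives 29200 nM in this assay.
Compound 3, `CCN1CCN(c2cc(C)c3cc(NC(=O)c4ccc(F)c(F)c4)ccc3n2)CC1`, gives 1980 nM in this assay.

Compound 2 sits second highest of these three numbers: the gap a 1.3-fold lower number from compound 1 to compound 2 (0.12 log units; within the scatter) is within the scatter, whereas the gap a 15-fold lower number from compound 2 to compound 3 (1.17 log units; beyond the scatter) is large. Compound 4, `CCN1CCN(c2cc(C)c3cc(NC(=O)c4cccc(C)c4)ccc3n2)CC1`, differs from compound 2 only in the aryl group on the amide: 3-methylphenyl in place of 2-methylphenyl on a carbonyl carbon.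

For the measured compounds named here, no measured step moves a methyl group alone between these two positions, so the closest guides are a 19-fold lower number from compound 1 to compound 3 (1.28 log units; beyond the scatter) and a 15-fold lower number from compound 2 to compound 3 (1.17 log units; beyond the scatter), where leaving the 2-position of the ring for substituents further out went with a large fall in the number. The same kind of move here is therefore expected to lower the number, though with a single methyl the size is uncertain, and a step of a 3.7-fold lower number from compound 2 to compound 4 (0.56 log units; beyond the scatter) is estimated. Compound 4 is thus expected to give about 8000 nM, within a range of 2000 nM to 30000 nM.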

Compound 4, half-maximal inhibitory concentration: 13700 nM
The estimate for compound 4 lay 1.7-fold (0.23 log units) below the measured number, within the range that was stated.
By their numbers in this assay, from the lowest: compound 3; then compound 4; then compounds 2 and 1 (each within the scatter of the next).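

Moving one methyl from 2-methylphenyl to 3-methylphenyl, with the same atoms on the same carbonyl carbon, gives a 2.1-fold lower number from compound 2 to compound 4 (0.33 log units; beyond the scatter) in this assay, so the place of this single group on the ring matters, although the effect is modest. The 3-methylphenyl group also does better than 2-fluorophenyl, with a 2.8-fold lower number from compound 1 to compound 4 (0.44 log units; beyond the scatter) on that swap, but it stays short of 3,4-difluorophenyl, with a 6.9-fold higher number from compound 3 to compound 4 (0.84 log units; beyond the scatter) on the reverse swap, so the methyl's move closes only part of the large gap seen earlier. Nothing available explains why this position affects the number.

On these data alone, it remains open whether 3-fluorophenyl or 3-aminophenyl on the same carbonyl carbon would come closer to compound 3 or to compound 4. As far as these compounds go, it is also open whether this order of aryl groups would hold in other cell lines.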